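Swapping One Five-Membered Ring for Another on a Shared Core

A few compounds are considered here, and "the series" means these few. Any claim that something is new, unique, unknown or untested is made for them only; others in the source may bear on it.

Compound 1 `c1ccc(-c2ccncc2)c(OCC2=NCCN2)c1`: in a functional assay for activation of Alpha-1B adrenergic receptor (Homo sapiens), read by calcium flux (on this read-out higher numbers stand for an effect only at larger amounts of compound and lower numbers for an effect already at smaller amounts), compound 1 gives only a limit, < 100000 nM.
Compound 2 `c1ccc(-c2ncc[nH]2)c(OCC2=NCCN2)c1`: in this assay compound 2 likewise gives only a limit, < 100000 nM.

Compound 2 thus stands at a limit of this assay rather than at a number, and the same is true of the other measured compound, as the limit of < 100000 nM in this assay, at which 2 of the 2 values shown sit, records. Within the data shown here, the only measured step, a step that the two limits leave unreadable from compound 1 to compound 2, cannot be read in size or direction, so it gives no measured anchor for what follows.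

Compound 3 `c1ccc(-c2nccs2)c(OCC2=NCCN2)c1` differs from compound 2 by 1,3-thiazol-2-yl in place of 1H-imidazol-2-yl on an aromatic carbon. Among the measured compounds shown here, no measured step with a readable size bears on this exchange; the one step that exists is unreadable. In this assay, for the measured compounds named here, no direction of change beyond the scatter can therefore be expected, only that compound 3 is likely to remain near or under the same limit that both measured compounds show. Compound 3 is expected to give 5000 nM in this assay, within the range 200 nM to 100000 nM, which corresponds to an expected step that the limit leaves unreadable from compound 2 to compound 3, a step that cannot be called real on the data at hand.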

Compound 3, half-maximal effective concentration: 20 nM
The estimate for compound 3 lay 250-fold (2.40 log units) above the measured number, and the stated range ends above it.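

No step from compound 1 or compound 2 to compound 3 can be read in size, because compound 1 and compound 2 each give only a limit and not a number: the limit of < 100000 nM in this assay, at which 2 of the 3 values shown sit.

Compound 3 gives 20 nM in this assay, but the compounds shown leave open how far it truly differs from compound 1 and compound 2.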